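A few compounds are considered here, and "the series" means these few. Any claim that something is new, unique, unknown or untested is made for them only; others in the source may bear on it.

In a functional assay on MCF7 cells (Homo sapiens) for antiproliferative activity, read by MTT assay, with a stated time of 72 h (a lower number here means a stronger inhibitor, a higher number a weaker inhibitor), compound 1 `O=C(N/N=C/c1cccc([N+](=O)[O-])c1)Nc1ccc(Oc2ccnc3[nH]ccc23)c(F)c1` gives "not active" (no number reported) and compound 2 `O=C(N/N=C/c1cccc(Cl)c1Cl)Nc1ccc(Oc2ccnc3[nH]ccc23)c(F)c1` gives "not active" (no number reported) as its result. Among the measured compounds shown here, compound 3 `O=C(N/N=C/c1ccc(O)cc1O)Nc1ccc(Oc2ccnc3[nH]ccc23)c(F)c1` gives 48000 nM as the only number among the tested compounds, so it has no second value to be ranked against. Going to compound 4 `O=C(N/N=C/c1cc(Br)c(O)c(Br)c1)Nc1ccc(Oc2ccnc3[nH]ccc23)c(F)c1` brings the change 3,5-dibromo-4-hydroxyphenyl in place of 2,4-dihydroxyphenyl on a carbon with a double bond to nitrogen with 3,5-dibromo-4-hydroxyphenyl in place of 2,4-dihydroxyphenyl on a carbon with a double bond to nitrogen. For the measured compounds named here, no two measured compounds form a step that differs in one place, so the size of this step has no precedent here. In this assay a shift toward a lower number is expected, of a size near the usual scatter, with compound 3 at 48000 nM as the only anchor, and a result without a number remains possible. The estimate means a 1.6-fold lower number from compound 3 to compound 4 (0.20 log units; within the scatter) on these numbers. For compound 4 the expected value is 30000 nM with a range from 9000 nM to 90000 nM in this estimate.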

Compound 4, half-maximal inhibitory concentration: "not active" (no number reported)
For compound 4 the study gives words and no number, and the estimate cannot be compared.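

Among the compounds shown here, compound 3 has a number while compound 4 is reported only in words, so no step between them can be read. The compounds shown leave open how each group affects antiproliferative activity. Nothing shown explains the result of compound 4.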